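Swapping Bromo for Methyl on the Fused Ring

A few compounds are considered here, and "the series" means these few. Any claim that something is new, unique, unknown or untested is made for them only; others in the source may bear on it.

Compound 2 `Clc1cccc(Nc2n[nH]c3ccc(Br)cc23)c1` stands lowest of the two numbers measured in an assay for inhibition of acyl-CoA (8-3)-desaturase (Homo sapiens) (a higher number here means a weaker inhibitor, a lower number a stronger inhibitor), giving 21 nM; its nearest neighbour, compound 1 `Clc1cccc(Nc2n[nH]c3ccccc23)c1`, gives 84 nM. Compound 3 `Cc1ccc2[nH]nc(Nc3cccc(Cl)c3)c2c1` differs from compound 2 by methyl in place of bromo on an aromatic carbon. Among the compounds with values here, the only measured step that bears on this carbon is a 4.0-fold lower number from compound 1 to compound 2 (0.60 log units; beyond the scatter), which shows that what sits there makes a modest difference. Compound 3 is expected to give back part of that gain, a step estimated as a 1.9-fold higher number from compound 2 to compound 3 (0.28 log units; within the scatter), possibly within the scatter. Compound 3 is therefore estimated at 40 nM, within a range from 15 nM to 110 nM.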

Compound 3, half-maximal inhibitory concentration: 6 nM
The estimate for compound 3 lay 6.7-fold (0.82 log units) above the measured number; the whole stated range lies above it.
By their numbers in this assay, from the lowest: compound 3; then compound 2; then compound 1.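

At this aromatic carbon, replacing hydrogen with bromo did not give the full gain available: methyl goes further (a 3.5-fold lower number from compound 2 to compound 3 (0.54 log units; beyond the scatter)). Measured against hydrogen, methyl brings a large change (a 14-fold lower number from compound 1 to compound 3 (1.15 log units; beyond the scatter)), so this single carbon matters more than compound 2 alone suggested. No evidence here accounts for methyl outperforming bromo. Going by these compounds, what remains open is how other groups on this carbon would compare with methyl. An ethyl, a methoxy or an amine could each keep this gain or lose it.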